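This account rests on a few compounds, and the source may have more. Where it says the series, first, only, none or still open, it means among the compounds named here.

Compound 1 `O=c1c(SC(=S)N2CCCCC2)coc2ccccc12` gives 17400 nM. Compound 2 `O=c1cc(CSC(=S)N2CCCC2)oc2ccccc12` gives > 30000 nM, a limit of the assay rather than a number. Compound 3 `O=c1cc(CSC(=S)N2CCCCC2)oc2ccccc12` gives > 25000 nM, likewise a limit.

Within the data shown here, in a functional assay on MDA-MB-435S cells (Homo sapiens) for antiproliferative activity, read by MTT assay, with a stated time of 72 h (on this read-out higher numbers stand for weaker inhibition and lower numbers for stronger inhibition), compound 1 therefore supplies the only number among the three measured compounds. Compound 3 and compound 2 differ by pyrrolidin-1-yl in place of piperidin-1-yl on a thiocarbonyl carbon, and the step that the two limits leave unreadable from compound 3 to compound 2 cannot be read because both values are limits the limit of > 25000 nM in this assay, at which 1 of the 3 values shown sits, and (the limit of > 30000 nM in this assay, at which 1 of the 3 values shown sits). The difference between the cores of compound 1 and compound 3 is not broken down here.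

Compound 4 `O=c1c(SC(=S)N2CCCC2)coc2ccccc12` differs from compound 1 by pyrrolidin-1-yl in place of piperidin-1-yl on a thiocarbonyl carbon, the same change as from compound 3 to compound 2. Since that earlier step is unreadable, the expectation rests alone on the value of compound 1, 17400 nM. Compound 4 is expected to stay close to that value, an estimated step of a 1.1-fold higher number from compound 1 to compound 4 (0.06 log units; within the scatter). Compound 4 is thus estimated at 20000 nM, within 7000 nM to 60000 nM.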

Compound 4, half-maximal inhibitory concentration: 1900 nM
The estimate for compound 4 lay 11-fold (1.02 log units) above the measured number; the measured number lies below the stated range.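

In this assay, pyrrolidin-1-yl in place of piperidin-1-yl on a thiocarbonyl carbon gives a 9.2-fold lower number from compound 1 to compound 4 (0.96 log units; beyond the scatter), so on the core of compound 1 this change shifts the read-out beyond the scatter. On the core of compound 3 the same change cannot be read, as both compounds there give limits of the assay, so the data neither confirm nor refute that the step carries from one core to the other. Compound 2, which carries pyrrolidin-1-yl on that core, gives a limit and not a number: the limit of > 30000 nM in this assay, at which 1 of the 4 values shown sits.

On these data alone, how morpholin-4-yl or a dimethylamino group on that thiocarbonyl carbon would compare with pyrrolidin-1-yl remains open. Also open, as far as these compounds go, is the size of this step on the core of compound 3.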